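A few compounds are considered here, and "the series" means these few. Any claim that something is new, unique, unknown or untested is made for them only; others in the source may bear on it.

Of the compounds shown here, two that share one core have been measured in an assay on cells for inhibition of mitogen-activated protein kinase kinase kinase 20 (Homo sapiens), read by ADP-Glo, with a stated time of 30 min; on this read-out lower numbers stand for stronger inhibition and higher numbers for weaker inhibition. Compound 1 `COc1n[nH]c2ncc(C#Cc3c(F)ccc(NS(=O)(=O)c4ccccc4)c3F)cc12` gives 19.2 nM. Compound 2 `COc1n[nH]c2ncc(C#Cc3c(F)ccc(NS(=O)(=O)c4ccccc4Cl)c3F)cc12`, which carries a chloro in place of a hydrogen on an aromatic carbon, gives 5.1 nM. That single change gave a 3.8-fold lower number from compound 1 to compound 2 (0.58 log units; beyond the scatter), so compound 2 stands with the lowest of the two numbers seen so far, and compound 1 is its nearest neighbour.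

Compound 3 `COc1n[nH]c2ncc(C#Cc3c(F)ccc(NS(=O)(=O)c4cccc(Cl)c4)c3F)cc12` has not yet been measured. It differs from compound 2 by 3-chlorophenyl in place of 2-chlorophenyl on a sulfonyl sulfur; the two have the same atoms, joined differently. For the measured compounds named here, only one measured step exists, a 3.8-fold lower number from compound 1 to compound 2 (0.58 log units; beyond the scatter), and it concerns adding the chloro at all, not shifting it from one carbon to another. It shows that the chloro counts, but gives no guide to which placement is preferable. Without a direct precedent, a step of modest size in either direction, or none beyond the scatter, is expected, with a slight lean towards a higher number since the placement that compound 2 shows with 5.1 nM is given up. Compound 3 is estimated at 9 nM, within 3 nM to 30 nM. That estimate means an expected step of a 1.8-fold higher number from compound 2 to compound 3 (0.25 log units; within the scatter).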

Compound 3, half-maximal inhibitory concentration: 4.2 nM
Estimate against measurement, compound 3: 2.1-fold (0.33 log units) above; the range from low to high includes it.
By their numbers in this assay, from the lowest: compounds 3 and 2 (each within the scatter of the next); then compound 1.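

Swapping 2-chlorophenyl for 3-chlorophenyl on the sulfonyl sulfur gives a 1.2-fold lower number from compound 2 to compound 3 (0.08 log units; within the scatter), so this assay does not tell these two chlorophenyl groups apart, a point that the earlier pair, which differed only in having a chloro or a hydrogen, could not address. Compound 3 also gives a second reading of that exchange of hydrogen for chloro, with a 4.6-fold lower number from compound 1 to compound 3 (0.66 log units; beyond the scatter), so both chlorophenyl compounds shown stand clear of the unsubstituted phenyl compound, and neither goes against this pattern. Nothing measured here explains why the two chlorophenyl groups read alike or why either differs from the plain phenyl group.

As far as these compounds go, three compounds cannot show whether this result is particular to chloro, and it remains open whether a bromo, a methyl or an amine on the same phenyl ring would match the chlorophenyl compounds or fall back towards compound 1 at 19.2 nM. Also open, from the compounds shown here alone, is whether a phenyl ring carrying two chloro groups would differ from those with one, and whether the same pattern would hold in any other measurement.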